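Cytotoxicity notes: from compound 3 to compound 4

A few compounds are considered here, and "the series" means these few. Any claim that something is new, unique, unknown or untested is made for them only; others in the source may bear on it.

In an ADME assay on HepG2 cells (Homo sapiens) for cytotoxicity, with a stated time of 72 h (a higher number here means that more compound is needed for the effect, a lower number that less compound is needed), compound 3 `Cc1cc(NC(=O)Nc2cccc(F)c2)c2ccccc2n1` gives > 25000 nM, which is a limit of the assay and not a number. This is the limit of > 25000 nM in this assay, at which 1 of the 3 values shown sits. The measured neighbours are compound 1 `Cc1cc(NC(=O)Nc2ccc(C(C)(C)C)cc2)c2ccccc2n1` at 17000 nM and compound 2 `CSc1ccc(NC(=O)Nc2cc(C)nc3ccccc23)cc1` at 16000 nM.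

Compound 4 `Cc1cc(NC(=O)Nc2ccc(O)cc2)c2ccccc2n1` carries 4-hydroxyphenyl in place of 3-fluorophenyl on an amide-type nitrogen. Going by the values given here, no measured step covers this exchange. The nearest evidence is the swap of methylsulfanyl for tert-butyl on an aromatic carbon, which gives a 1.1-fold lower number from compound 1 to compound 2 (0.03 log units; within the scatter). That step is small, but it involves different groups, so it bears on the present change only loosely. A small step in this assay is therefore expected, with any movement towards a lower number, and the result may again be only a limit. The expected step is an at least 1.1-fold lower number from compound 3 to compound 4 (0.05 log units; that floor lies within the scatter). For compound 4 the estimated value is 22000 nM, with an expected range from 10000 nM to 45000 nM.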

Compound 4, half-maximal effective concentration: > 25000 nM
Compound 4 gave a limit, no number (the forecaster's own chance of this, stated with the estimate: 45%); at least 1.1-fold (0.05 log units) between middle value and limit.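

In this assay compound 4 gives > 25000 nM, a limit and not a number, so 3-fluorophenyl and 4-hydroxyphenyl on the amide-type nitrogen now sit at the same limit: the limit of > 25000 nM in this assay, at which 2 of the 4 values shown sit.

The step between the two limits cannot be read, so this exchange has no size. Hydroxy in place of methylsulfanyl gives an at least 1.5-fold higher number from compound 2 to compound 4 (0.19 log units; that floor lies within the scatter), and hydroxy in place of tert-butyl gives an at least 1.4-fold higher number from compound 1 to compound 4 (0.16 log units; that floor lies within the scatter); both are floors, so the true size of each gap stays unknown.

Where compound 3 and compound 4 would fall as numbers remains open, as does whether an amine or a carboxylic acid in place of hydroxy would give a number instead of a limit. Any effect of a change to the shared core also lies outside these compounds.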